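Taking the Chloro Group off Compound 2

The source may hold more compounds than are shown below. What is called first, only, known or untested is meant among the compounds shown, and "the series" means these compounds.

In a functional assay on SK-N-SH cells (Homo sapiens) for cytotoxicity, read by MTT assay, with a stated time of 24 h (on this read-out higher numbers stand for weaker inhibition and lower numbers for stronger inhibition), compound 1 `Nc1cccn2cc(Cc3ccc(F)cc3)c(=O)nc12` gives 126000 nM, while compound 2 `O=c1nc2ccc(Cl)cn2cc1Cc1ccc(F)cc1` gives 9860 nM. Compound 2 therefore holds the lower of the two numbers, meaning the stronger inhibition, and the gap between them lies beyond the usual scatter. Compound 3 `O=c1nc2ccccn2cc1Cc1ccc(F)cc1` has yet to be measured in this assay. It differs from compound 2 in one place: hydrogen in place of chloro on an aromatic carbon. Within the data shown here, no measured pair shows this change on its own, so the expectation rests on two values only, with compound 2 at 9860 nM and compound 1 at 126000 nM. A moderate move towards weaker inhibition, beyond the scatter, is expected, with an estimated 2.8-fold higher number from compound 2 to compound 3 (0.45 log units; beyond the scatter). For compound 3 the estimate is 28000 nM, with an expected range of 9000 nM to 90000 nM.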

Compound 3, half-maximal inhibitory concentration: 125000 nM
Compound 3: middle estimate off by 4.5-fold (0.65 log units), on the low side; measured number above the stated range.
By their numbers in this assay, from the lowest: compound 2; then compounds 3 and 1 (each within the scatter of the next).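

In this assay, among these compounds, the chloro group, on the aromatic carbon two atoms from the ring nitrogen, proves to matter on its own: hydrogen in its place gives a 13-fold higher number from compound 2 to compound 3 (1.10 log units; beyond the scatter), a large step that no earlier pair could show. Hydrogen in place of amino on an aromatic carbon gives a 1.0-fold lower number from compound 1 to compound 3 (0.00 log units; within the scatter), so compound 1 and compound 3 cannot be told apart here, and among these compounds only the chloro group goes with the stronger inhibition. Nothing shown accounts for the size of the chloro step.

Going by these compounds, it remains open whether a bromo, methyl or methoxy group on this same carbon would keep the number of compound 2. Equally open, on these data alone, is whether chloro would act alike on another carbon of this ring.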